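A Larger Ester on the Nitrogen Chain

A few compounds are considered here, and "the series" means these few. Any claim that something is new, unique, unknown or untested is made for them only; others in the source may bear on it.

In a functional assay on HCT-15 cells (Homo sapiens) for cytotoxicity, read by colorimetric assay and MTT assay (a lower number here means a stronger inhibitor, a higher number a weaker inhibitor), compound 1 `CCOC(=O)Cn1c(=O)c(-c2ccc(OC)cc2)cc2c(OC)cc(OC)cc21` gives 10000 nM. Going by the values given here, compound 2 `COc1ccc(-c2cc3c(OC)cc(OC)cc3n(CC#N)c2=O)cc1`, the only other compound measured, gives 10000 nM, so compound 1 stands level with it. Compound 3 `COc1ccc(-c2cc3c(OC)cc(OC)cc3n(CCC(=O)OCc3ccccc3)c2=O)cc1` keeps the core of compound 1 and differs from it in one place: (benzyloxycarbonyl)methyl in place of ethoxycarbonyl on a saturated chain carbon bound to an aromatic nitrogen.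

Among the compounds with values here, only one measured step bears on this place, the replacement of ethoxycarbonyl by cyano, and its size is no change at the digits printed from compound 1 to compound 2 (within the scatter). That step is a thin guide, since neither compound 1 nor compound 2 has a six-membered aromatic ring of carbon only in this group, and the data do not show what such a ring does here. Given the step of no change at the digits printed from compound 1 to compound 2 (within the scatter), no change beyond the scatter is expected in this assay, in either direction. The expected step is a 1.1-fold lower number from compound 1 to compound 3 (0.05 log units; within the scatter). Compound 3 is estimated at 9000 nM, with an expected range from 3500 nM to 15000 nM.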

Compound 3, half-maximal inhibitory concentration: 10000 nM
For compound 3 the middle estimate is 1.1-fold (0.05 log units) below the measured one, within the range that was stated.
By their numbers in this assay, from the lowest: compounds 1, 2 and 3 (each within the scatter of the next).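

In this assay, going by these compounds alone, (benzyloxycarbonyl)methyl in place of ethoxycarbonyl on a saturated chain carbon bound to an aromatic nitrogen gives no change at the digits printed from compound 1 to compound 3 (within the scatter), the first reading at this place of a group holding a six-membered aromatic ring of carbon only. Replacing cyano with the same group gives no change at the digits printed from compound 2 to compound 3 (within the scatter). The entering group has 11 heavy atoms against 5 for ethoxycarbonyl, yet across ethoxycarbonyl, cyano and (benzyloxycarbonyl)methyl on the shared core, this position shows no step beyond the scatter.

Nothing available here accounts for this flat result.

The compounds shown leave open whether any group at this place can shift the number in this assay, since all three replacements so far are neutral and none carries a hydrogen-bond donor, and a carboxylic acid or an amine at the end of the chain would put that to the test. They also leave open whether a longer chain without an ester, or an unsubstituted ring nitrogen, would behave as these three do.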